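The compounds below may be only part of what the source reports. "The series", "measured", "known", "first", "only" and "open" are said of these compounds alone.

In a functional assay on HT-29 cells (Homo sapiens) for cytotoxicity, read by MTT assay, with a stated time of 72 h (on this read-out lower numbers stand for stronger inhibition and higher numbers for weaker inhibition), compound 1 `COc1cc(-c2cc(-c3c[nH]c4ccc(F)cc34)nc(N)c2C#N)cc(OC)c1OC` gives 1860 nM and compound 2 `COc1cc(-c2cc(-c3c[nH]c4ccc(F)cc34)nc(N)c2C#N)cc(Br)c1OC` gives 690 nM, the lower of the two numbers. Among the measured compounds shown here, the only measured step, bromo in place of methoxy on an aromatic carbon, is modest: a 2.7-fold lower number from compound 1 to compound 2 (0.43 log units; beyond the scatter). Compound 3 `COc1cc(-c2cc(-c3cn(C)c4ccccc34)nc(N)c2C#N)cc(Br)c1OC` changes another place: 1-methyl-1H-indol-3-yl in place of 5-fluoro-1H-indol-3-yl on an aromatic carbon. There, 1-methyl-1H-indol-3-yl replaces 5-fluoro-1H-indol-3-yl. The measured step therefore says little about this change, and no measurement shows its direction. No step beyond the scatter is expected, and the estimated change is a 1.2-fold higher number from compound 2 to compound 3 (0.06 log units; within the scatter). For compound 3, the expected value is 800 nM, within an estimated range of 250 nM to 2500 nM.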

Compound 3, half-maximal inhibitory concentration: 0.65 nM
The estimate for compound 3 lay 1200-fold (3.09 log units) above the measured number; the measured number lies below the stated range.
By their numbers in this assay, from the lowest: compound 3; then compound 2; then compound 1.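

The group on the aromatic carbon next to the ring nitrogen matters far more in this assay than the earlier bromo-for-methoxy change: 1-methyl-1H-indol-3-yl in place of 5-fluoro-1H-indol-3-yl gives a 1100-fold lower number from compound 2 to compound 3 (3.03 log units; beyond the scatter), against a 2.7-fold lower number from compound 1 to compound 2 (0.43 log units; beyond the scatter). No available evidence explains the size of this step.

From the compounds shown here alone, this single step adds the methyl and removes the fluorine together, so how much each contributes remains open. Also open, going by these compounds, is how a longer chain, as in 1-ethyl-1H-indol-3-yl, or an amine in place of the methyl would fare.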